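The source may hold more compounds than are shown below. What is called first, only, known or untested is meant among the compounds shown, and "the series" means these compounds.

Measured in a functional assay on MCF7 cells (Homo sapiens) for cytotoxicity, read by MTT assay, with a stated time of 72 h; on this read-out lower numbers stand for stronger inhibition and higher numbers for weaker inhibition:

compound 1 `COc1ccc(/C=C2\CCC/C(=C\c3ccc(Cl)cc3)C2=O)cc1OC` gives 6300 nM
compound 2 `COc1ccc(/C=C2\CCC/C(=C\c3ccc(Cl)c(Cl)c3)C2=O)cc1OC` gives 4400 nM
compound 3 `COc1cc(/C=C2\CCC/C(=C\c3ccc(OC)c(OC)c3)C2=O)ccc1O` gives 7900 nM

The three compounds share one core and differ only in the substituted phenyl groups attached to it. In this assay, compound 3 stands at 7900 nM, within the usual scatter of both other compounds. Compound 4 `COc1ccc(/C=C2\CCC/C(=C\c3ccc(O)c(O)c3)C2=O)cc1OC` has not yet been measured. It differs from compound 3 in one small detail: hydrogen in place of methyl on an oxygen on an aromatic ring. Hydrogen takes the place of methyl on an oxygen on an aromatic ring, so 4-hydroxy-3-methoxyphenyl becomes 3,4-dihydroxyphenyl.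

Among the compounds with values here, no measured pair makes this exact change. The closest evidence comes from exchanges of a whole substituted phenyl group: a 1.3-fold higher number from compound 1 to compound 3 (0.10 log units; within the scatter) and a 1.8-fold higher number from compound 2 to compound 3 (0.25 log units; within the scatter). Adding a chloro group gives a 1.4-fold lower number from compound 1 to compound 2 (0.16 log units; within the scatter). None of these steps exceeds the scatter, so no clear shift is expected from the smaller change here. The expected step is a 1.4-fold lower number from compound 3 to compound 4 (0.16 log units; within the scatter). Compound 4 is estimated at 5500 nM, with an expected range of 2000 nM to 14000 nM.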

Compound 4, half-maximal inhibitory concentration: 14400 nM
Compound 4: middle estimate off by 2.6-fold (0.42 log units), on the low side; measured number outside the range, above it.
By their numbers in this assay, from the lowest: compounds 2, 1, 3 and 4 (each within the scatter of the next, the first and the last beyond it).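

In this assay, hydrogen in place of methyl on an oxygen on an aromatic ring gives a 1.8-fold higher number from compound 3 to compound 4 (0.26 log units; within the scatter), so this single small change cannot be told apart from the usual spread of repeated measurements. Even so, compound 4 gives the first steps in this set that lie beyond the scatter, both modest: a 3.3-fold higher number from compound 2 to compound 4 (0.51 log units; beyond the scatter) and a 2.3-fold higher number from compound 1 to compound 4 (0.36 log units; beyond the scatter), each with 3,4-dihydroxyphenyl replacing a chlorine-bearing phenyl group. Nothing measured here accounts for these differences.

An ethyl group or a longer chain on that oxygen, or an amine in place of the hydroxy group, might or might not move the number beyond the scatter from compound 3. The two larger steps exchange a whole phenyl group at once, leaving open how much comes from gaining hydroxy groups and how much from losing chloro.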